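A few compounds are considered here, and "the series" means these few. Any claim that something is new, unique, unknown or untested is made for them only; others in the source may bear on it.

Compound 1 `C=CCOc1ccc2c(=O)c(-c3ccc(O)cc3)coc2c1`: 180 nM
Compound 2 `O=C(O)CCCCCCCOc1ccc2c(=O)c(-c3ccc(O)cc3)coc2c1`: 40 nM
Compound 3 `O=C(O)CCCCCCCCCOc1ccc2c(=O)c(-c3ccc(O)cc3)coc2c1`: 50 nM

These three share one core and differ only in the chain that hangs from an oxygen on the aromatic ring. In an assay (Cricetulus griseus) for inhibition of aldehyde dehydrogenase, mitochondrial (Homo sapiens) (a higher number here means a weaker inhibitor, a lower number a stronger inhibitor), compound 3 gives 50 nM, the second highest of the three numbers; compound 2 sits nearest with 40 nM, and compound 1 is furthest with 180 nM. Compound 4 `O=C(O)CCCCOc1ccc2c(=O)c(-c3ccc(O)cc3)coc2c1` has not yet been measured. Its difference from compound 3 is carboxy in place of 5-carboxypentyl on a saturated chain carbon, four bonds along the chain from an oxygen on an aromatic ring: the chain becomes much shorter while the carboxy end is kept. For the measured compounds named here, two measured steps bear on this. The step of a 4.5-fold lower number from compound 1 to compound 2 (0.65 log units; beyond the scatter) shows that a long carboxy-ended chain in place of a short vinyl group strengthened inhibition. The step of a 1.3-fold higher number from compound 2 to compound 3 (0.10 log units; within the scatter) shows that lengthening the carboxy chain further changed nothing beyond the scatter. Shortening the chain toward the length of compound 1 may therefore cost some potency, though the carboxy is retained. Compound 4 is expected to give 90 nM, between 35 nM and 250 nM, a step of a 1.8-fold higher number from compound 3 to compound 4 (0.26 log units; within the scatter) that is expected to be modest at most.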

Compound 4, half-maximal inhibitory concentration: 100 nM
Beside the measured number, compound 4's estimate is 1.1-fold (0.05 log units) below it; the range from low to high includes it.
By their numbers in this assay, from the lowest: compounds 2, 3, 4 and 1 (each within the scatter of the next, the first and the last beyond it).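

In this assay, shortening the carboxy-ended chain shows up clearly in one comparison, with a 2.5-fold higher number from compound 2 to compound 4 (0.40 log units; beyond the scatter) as the measured step, the first sign that the length of this chain matters and not only the presence of a carboxy end. The other two comparisons are smaller: a 2.0-fold higher number from compound 3 to compound 4 (0.30 log units; within the scatter) and a 1.8-fold lower number from compound 1 to compound 4 (0.26 log units; within the scatter) both lie within the scatter, so compound 4 cannot be told apart from compound 3 or from compound 1, which has no carboxy end at all. A carboxy end on this shorter chain therefore brings no measurable gain over compound 1, whereas the longer chain of compound 2 did.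

Nothing measured here explains why the length of this chain matters. A chain ending in an amine or an amide would show whether the carboxylic acid itself is needed at the chain end.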